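A methyl added on the phenyl of compound 2

The source may report more compounds than this note shows. Statements on the series, on what has been measured and on what is new or still open speak of the compounds shown alone.

Compound 1 `CC1(c2ccccc2)CC(=O)N(CC(=O)N2CCOCC2)C1=O`: 300 mg/kg
Compound 2 `CC1(c2ccccc2)CC(=O)N(CC(=O)N2CCN(c3ccccc3)CC2)C1=O`: 300 mg/kg

In a functional assay on the whole organism (strain CD-1) with Mus musculus as the target, with a stated time of 2 h (on this read-out lower numbers stand for an effect already at smaller amounts and higher numbers for an effect only at larger amounts of compound), compound 1 gives 300 mg/kg, and compound 2 gives 300 mg/kg. Compound 2 thus stands level with compound 1 at the digits shown, a difference within the usual scatter. Compound 3 `Cc1cccc(N2CCN(C(=O)CN3C(=O)CC(C)(c4ccccc4)C3=O)CC2)c1` is the next member; its change from compound 2 is methyl in place of hydrogen on an aromatic carbon. Going by the values given here, no measured step of this kind exists among the compounds above, so the account can only expect a small one: the expected step is no change at the digits printed from compound 2 to compound 3 (within the scatter), nothing beyond the scatter. Compound 3 is therefore estimated at 300 mg/kg, with a range from 150 mg/kg to 600 mg/kg.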

Compound 3, minimum effective dose: "not active" (no number reported)
The entry for compound 3 holds no number, so the estimate cannot be set against anything.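

Going by these compounds alone, compound 3 is reported as not active, without a number, in this assay, so no step from compound 2 to compound 3 can be read. The compounds shown leave open what dose, if any, compound 3 would act at. No evidence on the cause of this result is available.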